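This account rests on a few compounds, and the source may have more. Where it says the series, first, only, none or still open, it means among the compounds named here.

In a functional assay on HepG2 cells (Homo sapiens) for antiproliferative activity, read by MTT assay, with a stated time of 24 h (a lower number here means a stronger inhibitor, a higher number a weaker inhibitor), compound 3 (`COc1ccc(S(=O)(=O)n2c(-c3cn(-c4ccccc4)nc3-c3ccc(C(F)(F)F)cc3)nc3ccccc32)cc1`) gives 370 nM and sits within the scatter of compound 2 (`O=S(=O)(c1ccccc1)n1c(-c2cn(-c3ccccc3)nc2-c2ccc(C(F)(F)F)cc2)nc2ccccc21`) at 590 nM on the same read-out. Compound 1 (`O=[N+]([O-])c1ccc(S(=O)(=O)n2c(-c3cn(-c4ccccc4)nc3-c3ccc(F)cc3)nc3ccccc32)cc1`) at 1340 nM stands clearly higher than compound 3 does.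

The next change leads to compound 4 (`O=[N+]([O-])c1ccc(S(=O)(=O)n2c(-c3cn(-c4ccccc4)nc3-c3ccc(C(F)(F)F)cc3)nc3ccccc32)cc1`), with nitro in place of methoxy on an aromatic carbon, para to a large group: nitro in place of methoxy on an aromatic carbon is the full count.

For the measured compounds named here, one measured step touches this position: a 1.6-fold lower number from compound 2 to compound 3 (0.20 log units; within the scatter) for methoxy in place of hydrogen. Losing methoxy is therefore not expected, on that step alone, to move the number far. Going by the values given here, compound 1, the only measured compound with 4-nitrophenyl, gives 1340 nM and tilts the expectation towards a higher number. A modest upward step is thus expected in this assay, close to the edge of the scatter, and the evidence for it is thin.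

The expected move is a 1.9-fold higher number from compound 3 to compound 4 (0.28 log units; within the scatter) on this reading. Compound 4 is estimated at 700 nM within an expected range from 300 nM to 1600 nM for now.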

Compound 4, half-maximal inhibitory concentration: 1070 nM
For compound 4 the middle estimate is 1.5-fold (0.18 log units) below the measured one; measured number inside the range.
By their numbers in this assay, from the lowest: compounds 3, 2, 4 and 1 (each within the scatter of the next, the first and the last beyond it).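

In this assay, for the compounds shown here, nitro in place of methoxy on this aromatic carbon, para to a large group, gives a 2.9-fold higher number from compound 3 to compound 4 (0.46 log units; beyond the scatter), the first step at this position to clear the scatter. Hydrogen does not separate from either group: a 1.8-fold higher number from compound 2 to compound 4 (0.26 log units; within the scatter) for nitro and a 1.6-fold lower number from compound 2 to compound 3 (0.20 log units; within the scatter) for methoxy both stay within it, so only the methoxy and nitro pair is resolved. With 4-nitrophenyl in place, a 1.3-fold lower number from compound 1 to compound 4 (0.10 log units; within the scatter) for trifluoromethyl in place of fluoro also stays within the scatter, and no evidence is available to explain any of these steps.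

Still open, on these data alone, is where an amine or a carboxylic acid on this aromatic carbon would fall relative to methoxy and nitro. Also open, as far as these compounds go, is whether the methoxy and nitro gap persists when fluoro replaces trifluoromethyl.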